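Swapping a sulfonyl substituent in a leukemia cell growth series

This account rests on a few compounds, and the source may have more. Where it says the series, first, only, none or still open, it means among the compounds named here.

Compound 1: `COc1ccc(Cc2nnc(NC(=O)/C(C#N)=C/c3ccccc3OS(=O)(=O)c3ccccc3[N+](=O)[O-])s2)cc1` — 68%
Compound 2: `COc1ccc(Cc2nnc(NC(=O)/C(C#N)=C/c3ccccc3OS(=O)(=O)c3ccc(Cl)cc3)s2)cc1` — 79%
Compound 3: `N#C/C(=C\c1ccccc1OS(=O)(=O)c1ccccc1[N+](=O)[O-])C(=O)Nc1nnc(Cc2ccccc2)s1` — 71%

Of the compounds shown here, three have been tested in a functional assay on RS4-11 cells (Homo sapiens) for inhibition, read by CCK-8 assay, with a stated time of 48 h, tested at 20 uM; a higher number here means more inhibition of growth at the concentration tested, a lower number less inhibition of growth. In this assay compound 1 gives 68%, compound 2 gives 79%, and compound 3 gives 71%. Compound 1 and compound 2 differ in one place: 4-chlorophenyl in place of 2-nitrophenyl on a sulfonyl sulfur. That change gives a number 11 percentage points higher from compound 1 to compound 2 (beyond the scatter). Compound 1 and compound 3 differ at another spot: hydrogen in place of methoxy on an aromatic carbon. That change gives a number 3 percentage points higher from compound 1 to compound 3 (within the scatter), so compound 1 and compound 3 cannot be told apart in this assay. For the measured compounds named here, for compound 2 and compound 3 no step has been worked out; their two values lie within the scatter of each other.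

Compound 4, `N#C/C(=C\c1ccccc1OS(=O)(=O)c1ccc(Cl)cc1)C(=O)Nc1nnc(Cc2ccccc2)s1`, has not yet been measured. It differs from compound 3 in the same way that compound 2 differs from compound 1: 4-chlorophenyl in place of 2-nitrophenyl on a sulfonyl sulfur. The place is the same in both pairs, a sulfonyl sulfur whose other neighbour is an oxygen on an aromatic ring, so this is the same change, carried out on the core of compound 3 rather than on the core of compound 1. The two cores differ only in the way already described for compound 1 and compound 3.

Because the same change gave a number 11 percentage points higher from compound 1 to compound 2 (beyond the scatter), the estimated step ending at compound 4 is a number 11 percentage points higher from compound 3 to compound 4 (beyond the scatter). This rests on a single measured pair, so the expectation is uncertain. In this assay compound 4 is estimated at 82%, with the expected range running from 70% to 92%.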

Compound 4, percent growth inhibition at one concentration: 73%
Beside the measured number, compound 4's estimate is 9 percentage points above it; the measured number falls inside the stated range.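

In this assay, replacing 2-nitrophenyl with 4-chlorophenyl on the sulfonyl sulfur gives a number 2 percentage points higher from compound 3 to compound 4 (within the scatter), whereas the same change on the core of compound 1 gave a step beyond the scatter, yet the two steps cannot be told apart: the same change on two cores in this assay, a number 11 percentage points higher (beyond the scatter) from compound 1 to compound 2 and a number 2 percentage points higher (within the scatter) from compound 3 to compound 4, 9 percentage points apart, within the scatter of two such steps. The other change, hydrogen in place of methoxy on an aromatic carbon, gives a number 6 percentage points lower from compound 2 to compound 4 (within the scatter), and this step likewise cannot be told apart from its earlier counterpart: the same change on two cores in this assay, a number 3 percentage points higher (within the scatter) from compound 1 to compound 3 and a number 6 percentage points lower (within the scatter) from compound 2 to compound 4, 9 percentage points apart, within the scatter of two such steps. For the compounds shown here, these four compounds therefore show no measurable dependence of either change on the core, but they do not show that the sulfonyl change carries over reliably, as it stands beyond the scatter on only one of the two cores and its true size on either core remains unsettled.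

The compounds shown leave open how other groups on the sulfonyl sulfur, such as a methyl or a 4-aminophenyl group, would behave on these two cores. They also leave open whether a full concentration series would separate these compounds, as each number here comes from a single tested concentration.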